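The source may hold more compounds than are shown below. What is called first, only, known or untested is meant among the compounds shown, and "the series" means these compounds.

In an ADME assay (on this read-out higher numbers stand for a longer-lived compound and lower numbers for a shorter-lived compound), compound 2 `COc1ccc(C[S+]([O-])c2ncccc2C(=O)Nc2ccncc2)c(OCCF)c1` stands in the middle of three measured compounds at 3.3 h. The lowest number of the three comes from compound 1 `COc1ccc(C[S+]([O-])c2ncccc2C(=O)Nc2ccncc2)c(OC)c1` at 0.84 h. The highest comes from compound 3 `COc1cccc(OC)c1C[S+]([O-])c1ncccc1C(=O)Nc1ccncc1` at 38.5 h. The next compound, compound 4 `COc1ccc(C[S+]([O-])c2ncccc2C(=O)Nc2ccncc2)c(OCCO)c1`, carries a 2-hydroxyethoxy group where compound 2 has a 2-fluoroethoxy group: hydroxy in place of fluoro on a saturated chain carbon, two bonds along the chain from an oxygen on an aromatic ring. Within the data shown here, only one measured step bears on this chain, a 3.9-fold higher number from compound 1 to compound 2 (0.59 log units; beyond the scatter), a modest change that created the 2-fluoroethoxy group of compound 2. That step gives only a rough idea of how much changes on this chain can move the half-life. Among the measured compounds shown here, no measured pair swaps fluoro for hydroxy, so neither the size nor the direction of the new step is known. With so little to go on, no step beyond the scatter is expected, and the estimated step, leaning slightly downward, is a 1.3-fold lower number from compound 2 to compound 4 (0.12 log units; within the scatter). For compound 4 the expected half-life is 2.5 h, with an estimated range of 0.9 h to 7 h.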

Compound 4, half-life: 1.78 h
Estimate against measurement, compound 4: 1.4-fold (0.15 log units) above, and the stated range covers the measured number.
By their numbers in this assay, from the lowest: compound 1; then compounds 4 and 2 (each within the scatter of the next); then compound 3.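

In this assay, hydroxy in place of fluoro on this chain gives a 1.9-fold lower number from compound 2 to compound 4 (0.27 log units; within the scatter) and so does not separate the 2-hydroxyethoxy group from the 2-fluoroethoxy group on this read-out. The modest rise over the shorter methoxy group is therefore not tied to fluorine alone, since hydroxymethyl in place of hydrogen on the same carbon also gives a 2.1-fold higher number from compound 1 to compound 4 (0.33 log units; beyond the scatter) and stays beyond the scatter, as did the fluoromethyl change. No measurement here explains why these two end groups give such similar half-lives.

Only these two end groups are shown on this chain, so it stays open whether an amine or a carboxylic acid at the same place would fit the same picture. On these data alone, a longer chain carrying hydroxy or fluoro is equally open.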